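A few compounds are considered here, and "the series" means these few. Any claim that something is new, unique, unknown or untested is made for them only; others in the source may bear on it.

Measured compounds in a functional assay on K562 cells (Homo sapiens) for cytotoxicity, read by MTT assay, with a stated time of 72 h; a higher number here means a weaker inhibitor, a lower number a stronger inhibitor:
compound 1, `COc1ccc2c(c1)[n+]([O-])nc(NCOC(C)c1ccccc1)[n+]2[O-]` — 250 nM
compound 2, `[O-][n+]1nc(NCOC2CCCCC2)[n+]([O-])c2ccccc21` — 4880 nM
compound 3, `O=[N+]([O-])c1cccc(COCNc2n[n+]([O-])c3ccccc3[n+]2[O-])c1` — 650 nM

Among the three, compound 2 stands at the highest number, and so is the weakest inhibitor of the set; its gap to compound 3 is the smaller of the two and lies beyond the scatter, and its gap to compound 1 is wider still. Compound 4, `CCCCCOCNc1n[n+]([O-])c2ccccc2[n+]1[O-]`, has not yet been tested in this assay. It differs from compound 2 in one place: pentyl in place of cyclohexyl on an oxygen on a saturated carbon. Among the measured compounds shown here, nothing among the measured compounds records a change of this kind, so no measured step can be drawn on. The two groups are of similar size and neither adds a donor or an acceptor, and the expectation is therefore a step in this assay of no size beyond the scatter, in either direction. The step expected from compound 2 to compound 4 is a 1.1-fold higher number from compound 2 to compound 4 (0.05 log units; within the scatter). For compound 4 the estimated value in this assay is 5500 nM, with a range from 2200 nM to 14000 nM.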

Compound 4, half-maximal inhibitory concentration: 3300 nM
The estimate for compound 4 lay 1.7-fold (0.22 log units) above the measured number; the measured number falls inside the stated range.
By their numbers in this assay, from the lowest: compound 1; then compound 3; then compounds 4 and 2 (each within the scatter of the next).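

In this assay, putting pentyl in place of cyclohexyl on an oxygen on a saturated carbon gives a 1.5-fold lower number from compound 2 to compound 4 (0.17 log units; within the scatter). Among the compounds shown here, this is the only step in the set that isolates a change at this position, and it shows that, for this pair, an open chain and a six-membered carbon ring read alike, so the ring is not required to hold the number where it stands. No measured evidence at hand bears on why the two groups read alike.

Going by these compounds, it remains open whether a shorter chain such as ethyl, a longer chain such as octyl, or a chain ending in an amine or a carboxylic acid would also leave the number unmoved. On these data alone, it is equally open whether the same exchange would read alike on the core of compound 1.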